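This account rests on a few compounds, and the source may have more. Where it says the series, first, only, none or still open, it means among the compounds named here.

The three measured compounds share a core in which a five-membered aromatic ring with two nitrogens carries an aryl group on one aromatic nitrogen. In an assay on HEK-293T cells for inhibition of Bile acid receptor (Homo sapiens), read by a beta-lactamase reporter, with a stated time of 16 h (a higher number here means a weaker inhibitor, a lower number a stronger inhibitor), compound 1 `O=C(Nc1ccc(F)c(S(=O)(=O)N2CCOCC2)c1)c1cnn(-c2ccccc2)c1` gives 9400 nM. Compound 2 `Cc1ccc(-c2nn(-c3ccc(F)cc3)cc2C(=O)Nc2ccc(C)c(S(=O)(=O)N3CCOCC3)c2)cc1` gives 2490 nM, and compound 3 `Cc1ccc(-c2nn(-c3cccc(Cl)c3)cc2C(=O)Nc2ccc(C)c(S(=O)(=O)N3CCOCC3)c2)cc1` gives 5910 nM. Compound 3 thus holds the second-highest number of the three: compound 2 sits lower, beyond the scatter, while compound 1 lies within the scatter of compound 3. Compound 4 `Cc1ccc(-c2nn(-c3ccc(Cl)cc3Cl)cc2C(=O)Nc2ccc(C)c(S(=O)(=O)N3CCOCC3)c2)cc1` differs from compound 3 in one place: 2,4-dichlorophenyl in place of 3-chlorophenyl on an aromatic nitrogen. Going by the values given here, the only measured step at this aromatic nitrogen is a 2.4-fold higher number from compound 2 to compound 3 (0.38 log units; beyond the scatter), a modest change when one halogen pattern replaced another. Among the compounds with values here, no measured step shows two chlorines on this ring, so the direction of the present change is uncertain. Compound 4 is therefore expected to land close to compound 3, with a step of a 1.2-fold lower number from compound 3 to compound 4 (0.07 log units; within the scatter) that stays within the scatter. The estimate for compound 4 is 5000 nM, with a range from 1800 nM to 14000 nM.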

Compound 4, half-maximal inhibitory concentration: 1240 nM
Compound 4: the middle estimate sits 4.0-fold (0.61 log units) above what was measured; the measured number lies below the stated range.
By their numbers in this assay, from the lowest: compounds 4 and 2 (each within the scatter of the next); then compounds 3 and 1 (each within the scatter of the next).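

In this assay, the 2,4-dichlorophenyl group gives a 4.8-fold lower number from compound 3 to compound 4 (0.68 log units; beyond the scatter) and so shows that the number at this aromatic nitrogen can fall as well as rise, and that a ring with two chlorines is accepted here. The change to 2,4-dichlorophenyl from 4-fluorophenyl gives a 2.0-fold lower number from compound 2 to compound 4 (0.30 log units; within the scatter) and stays within the scatter, so compound 2 and compound 4 cannot be told apart, and both carry a halogen at the 4 position of this ring, while the 3-chlorophenyl of compound 3 does not. Nothing available explains this difference.

Which of the two chlorines matters stays open, as neither a 2-chlorophenyl nor a 4-chlorophenyl group is among the compounds shown. Also open, on these data alone, is how a ring bearing an amine or a carboxylic acid in place of halogen would behave at this nitrogen.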